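Aryl exchange on the shared core: expectation for compound 4

The source may report more compounds than this note shows. Statements on the series, on what has been measured and on what is new or still open speak of the compounds shown alone.

Measured so far in a functional assay on BJAB cells (Homo sapiens) for antiproliferative activity, with a stated time of 4 days; on this read-out lower numbers stand for an effect already at smaller amounts and higher numbers for an effect only at larger amounts of compound:
compound 1 `Cc1nn(-c2nc(-c3ccc(Cl)c(Cl)c3)c(SC(C)C)s2)c(C(=O)O)c1-c1cccc(C(F)(F)F)c1` gives 22000 nM
compound 2 `Cc1nn(-c2nc(-c3ccc(Cl)c(Cl)c3)c(SC(C)C)s2)c(C(=O)O)c1-c1cnccn1` gives 14000 nM
compound 3 `Cc1cccc(-c2c(C)nn(-c3nc(-c4ccc(Cl)c(Cl)c4)c(SC(C)C)s3)c2C(=O)O)c1` gives 17000 nM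

The three numbers sit close together: a 1.6-fold lower number from compound 1 to compound 2 (0.20 log units; within the scatter), a 1.3-fold lower number from compound 1 to compound 3 (0.11 log units; within the scatter) and a 1.2-fold higher number from compound 2 to compound 3 (0.08 log units; within the scatter). Compound 3 therefore lies within the scatter of both compound 1 and compound 2, and no ordering among the three can be read from these values; each aryl exchange so far has left the read-out essentially unchanged.

Compound 4 `CC(=O)Nc1ccc(-c2c(C)nn(-c3nc(-c4ccc(Cl)c(Cl)c4)c(SC(C)C)s3)c2C(=O)O)cc1` differs from compound 3 in one place: 4-acetamidophenyl in place of 3-methylphenyl on an aromatic carbon. Going by the values given here, the steps that bear on this exchange are the two aryl replacements, from compound 1 to compound 2 and from compound 2 to compound 3, both within the scatter. Among the compounds with values here, no measured compound carries an acetamido group, so there is nothing beyond those two steps to go on. The expectation in this assay is accordingly no step beyond the scatter, in either direction. The estimate for compound 4 is 17000 nM, with a range from 6000 nM to 50000 nM. The expected step is no change at the digits printed from compound 3 to compound 4 (within the scatter).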

Compound 4, half-maximal effective concentration: 139000 nM
The estimate for compound 4 lay 8.2-fold (0.91 log units) below the measured number, outside the stated range (above it).
By their numbers in this assay, from the lowest: compounds 2, 3 and 1 (each within the scatter of the next); then compound 4.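

In this assay, the position on the five-membered aromatic ring bearing these aryl groups proves sensitive to the exchange after all: 4-acetamidophenyl gives an 8.2-fold higher number from compound 3 to compound 4 (0.91 log units; beyond the scatter), a 9.9-fold higher number from compound 2 to compound 4 (1.00 log units; beyond the scatter) and a 6.3-fold higher number from compound 1 to compound 4 (0.80 log units; beyond the scatter), all beyond the scatter, whereas the earlier exchanges stayed within it. 3-Methylphenyl, 3-(trifluoromethyl)phenyl and pyrazin-2-yl therefore do not show the full range at this position, and compound 4 alone stands apart among the four compounds. The entering group differs from 3-methylphenyl in heavy-atom count, in its hydrogen-bond donor and acceptor and in its substitution pattern, and nothing available explains the step.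

As far as these compounds go, it remains open whether the acetamido group as a whole or the substitution pattern accounts for the step. 4-Aminophenyl, with a free amine, and 3-acetamidophenyl would help separate these features.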